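The source may hold more compounds than are shown below. What is called first, only, known or untested is meant among the compounds shown, and "the series" means these compounds.

Measured compounds:
Compound 1, `CC(C(=O)NCc1ccc(C(F)(F)F)nc1N(C)C)c1ccc(NS(C)(=O)=O)c(F)c1`: 19.1 nM
Compound 2, `C[C@H](C(=O)NCc1ccc(C(F)(F)F)nc1N1CC[C@@H](N(C)C)C1)c1ccc(NS(C)(=O)=O)c(F)c1`: 101 nM
Compound 3, `CC(C(=O)NCc1ccc(C(F)(F)F)nc1N1CCC(Cc2cc(F)cc(F)c2)CC1)c1ccc(NS(C)(=O)=O)c(F)c1`: 0.4 nM

These three compounds were tested in a functional assay on CHO-K1 cells for antagonist activity at transient receptor potential cation channel subfamily V member 1 (Homo sapiens), read by FLIPR; a higher number here means a weaker inhibitor, a lower number a stronger inhibitor. Compound 1 gives 19.1 nM and stands second highest of the three numbers. Its nearest neighbour is compound 2, which gives 101 nM, a weaker result and beyond the usual scatter. Furthest away is compound 3, which gives 0.4 nM, far stronger than compound 1 and well beyond the scatter.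

Compound 4, `CC(C(=O)NCc1ccc(C(F)(F)F)nc1N1CCN(C)CC1)c1ccc(NS(C)(=O)=O)c(F)c1`, has not yet been measured. It differs from compound 1 in one place: 4-methylpiperazin-1-yl in place of dimethylamino on an aromatic carbon. Among the measured compounds shown here, no pair of measured compounds shows this exact change, so the size of the step is open. Among the measured compounds, compound 2 carries a ring group in that place and gives 101 nM, a weaker result than compound 1. Compound 4 is therefore expected to lose some potency relative to compound 1, with an expected step of a 3.1-fold higher number from compound 1 to compound 4 (0.50 log units; beyond the scatter), likely beyond the scatter. For compound 4 in this assay the estimate is 60 nM, with a range from 15 nM to 250 nM.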

Compound 4, inhibition constant: 146 nM
For compound 4 the middle estimate is 2.4-fold (0.39 log units) below the measured one; low and high end bracket the measured number.
By their numbers in this assay, from the lowest: compound 3; then compound 1; then compounds 2 and 4 (each within the scatter of the next).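

In this assay, among the compounds shown here, putting 4-methylpiperazin-1-yl in place of dimethylamino on this aromatic carbon produces a 7.6-fold higher number from compound 1 to compound 4 (0.88 log units; beyond the scatter) as a modest loss of potency, the first direct reading of a single change at this position. A ring here does not by itself bring that loss: compound 3, which also carries a ring group in this place, gives 0.4 nM in the same assay, so what the ring carries seems to matter. Nothing measured here explains why the piperazine costs potency.

Still open, from the compounds shown here alone, is whether the methyl on the piperazine nitrogen plays any part, which piperazin-1-yl with a hydrogen there would test. Morpholin-4-yl, with oxygen in place of that nitrogen, would show whether the second ring nitrogen is needed at all.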